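This account rests on a few compounds, and the source may have more. Where it says the series, first, only, none or still open, it means among the compounds named here.

Measured compounds:
Compound 1, `CC(=O)Nc1ccc(-c2nc3ccccc3[nH]2)cc1`: 100000 nM
Compound 2, `CC(=O)Nc1ccc(-c2nc3cc(C(F)(F)F)ccc3[nH]2)cc1`: 19000 nM

In an ADME assay on MT4 cells (Homo sapiens) for cytotoxicity, read by MTT assay, with a stated time of 96 h (on this read-out higher numbers stand for lower toxicity in this test and lower numbers for higher toxicity in this test), compound 1 gives 100000 nM, the highest of the two numbers in hand. Going by the values given here, its one neighbour with a single change is compound 2, which in this assay gives 19000 nM; the step is a 5.3-fold lower number from compound 1 to compound 2 (0.72 log units; beyond the scatter), and it places trifluoromethyl in place of hydrogen on an aromatic carbon.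

The compound now in question, compound 3, `O=C(CN1CCCCC1)Nc1ccc(-c2nc3ccccc3[nH]2)cc1`, differs from compound 1 by piperidin-1-yl in place of hydrogen on a saturated chain carbon bound to a carbonyl carbon. This change sits on a saturated chain carbon bound to a carbonyl carbon, far from the aromatic carbon altered in compound 2, so the measured step from compound 1 to compound 2 bears on it only loosely: it shows that a single substituent added to the shared core of compound 1 can lower the number by a modest amount, but says nothing specific about a piperidin-1-yl group on the chain. Among the compounds with values here, with no closer precedent, compound 3 is expected to land near compound 1, with at most a small to modest lowering, as a 1.7-fold lower number from compound 1 to compound 3 (0.22 log units; within the scatter). Compound 3 is therefore estimated at 60000 nM, in the range 15000 nM to 150000 nM.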

Compound 3, half-maximal cytotoxic concentration: 31000 nM
Estimate against measurement, compound 3: 1.9-fold (0.29 log units) above, and the stated range covers the measured number.
By their numbers in this assay, from the lowest: compounds 2 and 3 (each within the scatter of the next); then compound 1.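

In this assay the saturated chain carbon bound to a carbonyl carbon proves to be a place where the number responds, and the change of methyl to (piperidin-1-yl)methyl gives a 3.2-fold lower number from compound 1 to compound 3 (0.51 log units; beyond the scatter). Going by these compounds alone, the only earlier step lay on an aromatic carbon, so a lowering of the number is now seen at a second, separate place on the core of compound 1, and here the entering group of 6 heavy atoms brings a modest step rather than a large one. Nothing at hand accounts for the size or direction of this step.

The compounds shown leave open whether the step belongs to the six-membered ring itself or to any amine on this carbon, a question that dimethylamino, morpholin-4-yl or a carboxylic acid in the same place would address, as would a longer chain between the carbonyl and the piperidin-1-yl group. They also leave open what happens when trifluoromethyl and piperidin-1-yl stand together on the shared core, and whether their two steps would then add up.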